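Methyl removal on the saturated ring of compound 2

The compounds below may be only part of what the source reports. "The series", "measured", "known", "first", "only" and "open" are said of these compounds alone.

Measured so far in a functional assay on ileum for antagonist activity at Substance-P receptor (Cavia porcellus); on this read-out lower numbers stand for stronger inhibition and higher numbers for weaker inhibition:
compound 1 `Cc1ccccc1-c1ncnc2c1C(=O)N(Cc1cc(C(F)(F)F)cc(C(F)(F)F)c1)C[C@@H](C)CO2`, 162 nM
compound 2 `Cc1ccccc1-c1ncnc2c1C(=O)N(Cc1cc(C(F)(F)F)cc(C(F)(F)F)c1)C[C@H](C)CO2`, 12.6 nM

Going by the values given here, compound 2 stands lowest of the two numbers in this assay, with compound 1 as its only neighbour, the step being a 13-fold lower number from compound 1 to compound 2 (1.11 log units; beyond the scatter). That step rests on (the fact that compounds 1 and 2 differ only in the configuration as drawn), the configuration at the saturated ring carbon bearing the methyl.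

Compound 3 `Cc1ccccc1-c1ncnc2c1C(=O)N(Cc1cc(C(F)(F)F)cc(C(F)(F)F)c1)CCCO2` is not yet measured. It differs from compound 2 by hydrogen in place of methyl on a saturated ring carbon, so the stereocentre that separates compounds 1 and 2 is removed altogether. Among the compounds with values here, the only step measured so far bears on this change indirectly: it shows that the methyl and its configuration move the number a great deal in this assay. With the methyl absent, compound 3 is expected to fall between the two measured values, nearer compound 2. The expected step is a 3.2-fold higher number from compound 2 to compound 3 (0.50 log units; beyond the scatter). For compound 3 the estimate in this assay is 40 nM, within 10 nM to 160 nM.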

Compound 3, antagonist equilibrium constant: 11.6 nM
Estimate against measurement, compound 3: 3.4-fold (0.54 log units) above; the range from low to high includes it.
By their numbers in this assay, from the lowest: compounds 3 and 2 (each within the scatter of the next); then compound 1.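

In this assay hydrogen and the methyl as drawn in compound 2 cannot be told apart on this saturated ring carbon (a 1.1-fold lower number from compound 2 to compound 3 (0.04 log units; within the scatter)). The same replacement starting from the other configuration gives a large step (a 14-fold lower number from compound 1 to compound 3 (1.15 log units; beyond the scatter)), so of the two methyl compounds only compound 1 stands apart from the compound without the methyl. The wide gap between the two methyl compounds therefore reads as a weakening tied to the methyl as drawn in compound 1, not as a gain from the methyl as drawn in compound 2, and configuration is all that separates this pair: the fact that compounds 1 and 2 differ only in the configuration as drawn.

Open, on these data alone, is how an ethyl, a hydroxyl or an amine on this ring carbon would read in this assay. Also open, as far as these compounds go, is whether a second methyl on the same carbon would read like compound 1 or like compound 3.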